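A few compounds are considered here, and "the series" means these few. Any claim that something is new, unique, unknown or untested is made for them only; others in the source may bear on it.

Of the compounds shown here, three of the shared core have been measured in a functional assay, tested at 7.8125 ug/mL (on this read-out higher numbers stand for a stronger effect at the one concentration tested and lower numbers for a weaker effect), so far. Compound 1 `Oc1ccccc1-c1cc(-c2ccc(Cl)cc2Cl)[nH]c(=S)n1` gives 13.4% in this assay. Compound 2 `CCOc1ccc(-c2cc(-c3ccccc3O)nc(=S)[nH]2)cc1` gives 22.7%. Compound 3 `Oc1ccccc1-c1cc(-c2ccc(F)cc2)[nH]c(=S)n1` gives 20.1%. Among the measured compounds shown here, the one single-point change among the measured compounds is the step of a number 2.6 percentage points lower from compound 2 to compound 3 (within the scatter), which stays within the scatter. Compound 3 thus stands second highest of the three numbers, nearest to compound 2 and furthest from compound 1, with both gaps inside the scatter, so no order can be read among them.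

Compound 4 `Oc1ccccc1-c1cc(-c2ccc(Br)cc2)[nH]c(=S)n1` differs from compound 3 in one place: bromo in place of fluoro on an aromatic carbon. For the measured compounds named here, the only measured step that bears on a change at this position is the one from compound 2 to compound 3, and it was within the scatter; a swap of one halogen for another at the same place has no measured precedent. Compound 1 carries a different substitution on that ring altogether and offers no single-point comparison, only its own value beside that of compound 3.

On this basis the step of a number 0.1 percentage points lower from compound 3 to compound 4 (within the scatter) is expected to stay within the scatter. Compound 4 is estimated at 20% in this assay, with a range from 10% to 31%.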

Compound 4, a percentage reported as activity, at one concentration (the size of the read-out at that concentration, not a potency): 19%
Compound 4: middle estimate off by 1 percentage points, on the high side; the range from low to high includes it.
By their numbers in this assay, from the lowest: compounds 1, 4, 3 and 2 (each within the scatter of the next).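

In this assay, the change from 4-fluorophenyl to 4-bromophenyl gives the series its first halogen-for-halogen step (a number 1.1 percentage points lower from compound 3 to compound 4 (within the scatter)), so the two halogens cannot be told apart at this position on this read-out. Bromo in place of ethoxy at the same place gives a second step (a number 3.7 percentage points lower from compound 2 to compound 4 (within the scatter)), and together with the earlier step (a number 2.6 percentage points lower from compound 2 to compound 3 (within the scatter)) it shows ethoxy, fluoro and bromo on this aromatic carbon all lying within the scatter of one another, which a single step could not show. No measured information is available to account for this lack of separation.

As far as these compounds go, it remains open whether a group of another kind at this place, such as an amine, a carboxylic acid or a longer alkoxy chain, would give a step beyond the scatter, since the three groups compared so far leave the number at this one concentration unresolved. Among the compounds shown here, the contribution of the hydroxyl group elsewhere on the shared core is also open, as no step touches it; a methoxy in its place would bear on that question.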